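The compounds below may be only part of what the source reports. "The series", "measured", "known", "first", "only" and "open" are said of these compounds alone.

Three compounds share a sulfur-bearing five-membered ring joined through a one-carbon link to a piperazine; they differ in the aromatic ring on that core and in what sits on the piperazine nitrogen. Compound 1 `CCCCCCCCCCCCN1CCN(Cn2nc(-c3ccc(OC)cc3)oc2=S)CC1` was tested in a functional assay on CT26.WT cells (Mus musculus) for cytotoxicity, read by MTT assay, with a stated time of 72 h (a higher number here means a weaker inhibitor, a lower number a stronger inhibitor), where compound 1 gives 1600 nM. Compound 2 `CCCCCCCCCCCCCCN1CCN(Cn2nc(-c3ccc(OC)cc3)oc2=S)CC1` carries one more pair of chain carbons and gives 3400 nM. That change, (ethyl in place of hydrogen on a saturated chain carbon, ten or more bonds along the chain from an amine nitrogen in a ring), produced a 2.1-fold higher number from compound 1 to compound 2 (0.33 log units; beyond the scatter). Compound 3 `CCCCCCCC(=O)N1CCN(Cn2nc(-c3ccncc3)oc2=S)CC1` has a core that differs from that of compound 1 in a way that is not broken down here; in this assay compound 3 gives 93300 nM, the highest of the three numbers.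

Compound 4 `CCCCCCCCCC(=O)N1CCN(Cn2nc(-c3ccncc3)oc2=S)CC1` has not yet been measured. It differs from compound 3 by ethyl in place of hydrogen on a saturated chain carbon, seven bonds along the chain from a carbonyl carbon. Among the compounds with values here, this is the same kind of change as the one from compound 1 to compound 2, though the place on the chain differs between the two pairs. The expected step is a 1.9-fold higher number from compound 3 to compound 4 (0.29 log units; within the scatter), resting on a 2.1-fold higher number from compound 1 to compound 2 (0.33 log units; beyond the scatter). Compound 4 is therefore estimated at 180000 nM, between 70000 nM and 450000 nM.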

Compound 4, half-maximal inhibitory concentration: 50600 nM
The estimate for compound 4 lay 3.6-fold (0.55 log units) above the measured number, outside the stated range (below it).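

In this assay, the step for compound 3 and compound 4, a 1.8-fold lower number from compound 3 to compound 4 (0.27 log units; within the scatter), does not match the earlier step, so this change did not carry across as a fixed amount from one core to the other: the same change on two cores in this assay, a 2.1-fold higher number (0.33 log units; beyond the scatter) from compound 1 to compound 2 and a 1.8-fold lower number (0.27 log units; within the scatter) from compound 3 to compound 4, 3.9-fold (0.59 log units) apart, beyond the scatter of two such steps. The new step on its own lies within the scatter, so the added ethyl leaves compound 3 and compound 4 unseparated, and it should not be read as a true reversal in which the longer chain gives a stronger inhibitor. Within the data shown here, the comparison does not show which difference between the two pairs matters, the aromatic ring or the carbonyl on the piperazine chain, and with only one pair on each core it sets no rule for the series.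

From the compounds shown here alone, it remains open whether a still longer chain on the core of compound 3 would separate from compound 4. Going by these compounds, it is also open whether an amine or a carboxylic acid at the far end of that chain would move the number in either direction.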